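The compounds below may be only part of what the source reports. "The series", "measured", "known", "first", "only" and "open" are said of these compounds alone.

Measured compounds, all in a functional assay for inhibition, with Rattus norvegicus as the target; on this read-out higher numbers stand for weaker inhibition and lower numbers for stronger inhibition:

Compound 1 `CC(C)(C)/N=c1\c(O)c(O)\c1=N/c1cccnc1` gives 2800 nM.
Compound 2 `COc1ncccc1/N=c1\c(O)c(O)\c1=N/C(C)(C)C` gives 2560 nM.
Compound 3 `CC(/N=c1\c(O)c(O)\c1=N/c1cccc2cccnc12)C(C)(C)C` gives 8100 nM.

Compound 1 and compound 2 share a core and differ in one place: methoxy in place of hydrogen on an aromatic carbon. In this assay this change made a 1.1-fold lower number from compound 1 to compound 2 (0.04 log units; within the scatter), so the two numbers cannot be told apart. Compound 3 has a different core; how the two cores differ is not broken down here. Its number in this assay is the highest of the three, and its gap to compound 1 and to compound 2 lies beyond the scatter.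

Compound 4 `COc1cc(/N=c2\c(O)c(O)\c2=N/C(C)C(C)(C)C)c2ncccc2c1` has not yet been measured. It differs from compound 3 by methoxy in place of hydrogen on an aromatic carbon. Among the measured compounds shown here, this is the same kind of change as the one from compound 1 to compound 2, not the same: there the methoxy entered on a six-membered aromatic ring with one nitrogen, next to the ring nitrogen and ortho to a large group; here it enters on a six-membered aromatic ring of carbon only, part of a fused system of two rings, meta to a fused ring, meta to a large group and para to a fused ring. Because the earlier example of this change was a 1.1-fold lower number from compound 1 to compound 2 (0.04 log units; within the scatter), the step expected in this assay is a 1.1-fold lower number from compound 3 to compound 4 (0.03 log units; within the scatter), with wider uncertainty since the surroundings differ. Compound 4 is therefore estimated at 7500 nM, between 3000 nM and 19000 nM.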

Compound 4, half-maximal inhibitory concentration: > 30000 nM
Compound 4 gave a limit, no number; the forecaster's own chance of this, stated with the estimate: 5%; middle value at least 4.0-fold (0.60 log units) away from the limit.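

In this assay, methoxy in place of hydrogen on an aromatic carbon of the core of compound 3 produced a clear shift toward weaker inhibition, with an at least 3.7-fold higher number from compound 3 to compound 4 (0.56 log units; beyond the scatter). Compound 4 gives > 30000 nM, which is a limit of the assay and not a number: the limit of > 30000 nM in this assay, at which 1 of the 4 values shown sits. Among the compounds shown here, the effect of this change on one core therefore cannot simply be carried over to the other, but with only one pair per core and the methoxy sitting in a different place on each, this does not show whether the core or the place accounts for the gap: the same change on two cores in this assay, a 1.1-fold lower number (0.04 log units; within the scatter) from compound 1 to compound 2 and an at least 3.7-fold higher number (0.56 log units; beyond the scatter) from compound 3 to compound 4, at least 4.0-fold (0.60 log units) apart, beyond the scatter of two such steps.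

The compounds shown leave open how an amine or an ethoxy group on that same aromatic carbon would read in this assay. They also leave open whether methoxy in place of hydrogen would give a step nearer to the first or the second on a third core.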